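The source may report more compounds than this note shows. Statements on the series, on what has been measured and on what is new or still open speak of the compounds shown alone.

Measured compounds in an assay on isolated protein for inhibition of Fatty-acid amide hydrolase 1 (Homo sapiens); a lower number here means a stronger inhibitor, a higher number a weaker inhibitor:
compound 1 `O=C(CCCC1CCN(Cc2ccccc2)CC1)c1ncco1`: 315 nM
compound 2 `O=C(CCCC1CCN(Cc2ccc(Cl)cc2)CC1)c1ncco1`: 66 nM

Compound 2 gives the lower of the two numbers in this assay; the gap to compound 1 is the step of a 4.8-fold lower number from compound 1 to compound 2 (0.68 log units; beyond the scatter), beyond the scatter.

Compound 3 `O=C(CCCC1CCN(Cc2cccc(Br)c2)CC1)c1ncco1` differs from compound 2 by 3-bromophenyl in place of 4-chlorophenyl on a saturated chain carbon bound to an amine nitrogen in a ring. Within the data shown here, the only measured step, a 4.8-fold lower number from compound 1 to compound 2 (0.68 log units; beyond the scatter), concerns chloro in place of hydrogen; no step covers bromo in place of chloro or the other placement on the ring, so the expected change in this assay is small, with no direction beyond the scatter. Compound 3 is estimated at 80 nM, range 25 nM to 250 nM, an expected step of a 1.2-fold higher number from compound 2 to compound 3 (0.08 log units; within the scatter).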

Compound 3, half-maximal inhibitory concentration: 10 nM
Beside the measured number, compound 3's estimate is 8.0-fold (0.90 log units) above it, and the stated range ends above it.
By their numbers in this assay, from the lowest: compound 3; then compound 2; then compound 1.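

In this assay, 3-bromophenyl in place of 4-chlorophenyl gives a 6.6-fold lower number from compound 2 to compound 3 (0.82 log units; beyond the scatter) on a saturated chain carbon bound to an amine nitrogen in a ring, so the chloro result does not mark the limit for this aromatic group. Bromo in place of hydrogen gives a 32-fold lower number from compound 1 to compound 3 (1.50 log units; beyond the scatter) as a large step, whereas chloro in place of hydrogen gives the modest 4.8-fold lower number from compound 1 to compound 2 (0.68 log units; beyond the scatter). No measured evidence accounts for this gain. The halogen and its placement change together, so their contributions cannot be separated. The 3-chlorophenyl and 4-bromophenyl analogues would separate them, and a 3-methoxyphenyl group would test whether a halogen is needed at all.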